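Chloro for nitro on the shared core: cytotoxicity expectation

The source may hold more compounds than are shown below. What is called first, only, known or untested is meant among the compounds shown, and "the series" means these compounds.

Of the compounds shown here, two have a number so far. Compound 1 `CN1CCC(NC(=O)c2ccc(Nc3ncc([N+](=O)[O-])c(NC4CCCC4)n3)cc2)CC1` is the nitro-bearing amide; in a functional assay on HeLa cells (Homo sapiens) for cytotoxicity, read by MTT assay, with a stated time of 48 h (a lower number here means a stronger inhibitor, a higher number a weaker inhibitor), compound 1 gives 21700 nM. Compound 2 `CN1CCN(c2ccc(Nc3ncc(F)c(NC4CCCC4)n3)cc2)CC1` carries a fluoro on the same position of the core and a different amine on the outer ring; in this assay compound 2 gives 20000 nM. Compound 1 holds the highest of the two numbers, but its nearest neighbour, compound 2, lies within the scatter of it, so the two are not told apart.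

Within the data shown here, compound 3 `CN1CCC(NC(=O)c2ccc(Nc3ncc(Cl)c(NC4CCCC4)n3)cc2)CC1` is the next compound and keeps the amide of compound 1; the single change is chloro in place of nitro on an aromatic carbon. Among the measured compounds shown here, no measured pair isolates this exchange, so no step can be read from the data. For the measured compounds named here, both known numbers sit weakly in the same region, and with no anchor the step from compound 1 to compound 3 is expected to stay within the scatter, in either direction, as a 1.2-fold higher number from compound 1 to compound 3 (0.06 log units; within the scatter). For compound 3 the expected value in this assay is therefore 25000 nM, with a range from 8000 nM to 70000 nM.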

Compound 3, half-maximal inhibitory concentration: 1500 nM
Beside the measured number, compound 3's estimate is 17-fold (1.22 log units) above it; measured number below the stated range.
By their numbers in this assay, from the lowest: compound 3; then compounds 2 and 1 (each within the scatter of the next).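

In this assay, among these compounds, chloro in place of nitro on the aromatic carbon ortho to a cyclopentylamino group gives a 14-fold lower number from compound 1 to compound 3 (1.16 log units; beyond the scatter), the first step that can be read. With the amide of compound 1 held fixed, this position is shown not to be indifferent: the earlier numbers could not show this, as the only two compounds then measured differ in more than one place and lie within the scatter of each other. No measurement shown bears on what lies behind the size of this step.

On these data alone, whether the step reflects the arrival of chloro or the departure of nitro remains open, and hydrogen, bromo, methyl or nitrile on the same aromatic carbon, with the amide of compound 1 kept, would help separate the two readings. As far as these compounds go, compound 2 differs from compound 3 both in fluoro on this carbon and in the amine on the outer ring, so steps involving compound 2 cannot be read, and the separate contribution of each of those two places stays unknown.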